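Hydrazone series: chloro added to the 2-hydroxyphenyl arm

The source may report more compounds than this note shows. Statements on the series, on what has been measured and on what is new or still open speak of the compounds shown alone.

Measured so far:
compound 1 `Cc1c(C(=O)N/N=C\c2ccc(O)cc2)oc2cccc(O)c12` — 21700 nM
compound 2 `Cc1c(C(=O)N/N=C\c2ccccn2)oc2cccc(O)c12` — >= 40000 nM (a limit of the assay)
compound 3 `Cc1c(C(=O)N/N=C\c2ccccc2O)oc2cccc(O)c12` — 8350 nM

In a functional assay on PC-3 cells (Homo sapiens) for inhibition (on this read-out higher numbers stand for weaker inhibition and lower numbers for stronger inhibition), compound 1 gives 21700 nM. Compound 2 reaches only a limit of the assay, >= 40000 nM. Compound 3 gives 8350 nM, the lowest of the two numbers shown; the nearest step is a 2.6-fold lower number from compound 1 to compound 3 (0.41 log units; beyond the scatter), and the step from the limit is an at least 4.7-fold lower number from compound 2 to compound 3 (0.68 log units; beyond the scatter).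

Compound 4 `Cc1c(C(=O)N/N=C\c2cc(Cl)ccc2O)oc2cccc(O)c12` differs from compound 3 by chloro in place of hydrogen on an aromatic carbon. Both measured steps exchange the whole group on the carbon with a double bond to nitrogen; none alters a substituent within the 2-hydroxyphenyl, so none bears directly on this change. The expected step is therefore a 1.3-fold lower number from compound 3 to compound 4 (0.11 log units; within the scatter), within the scatter. Compound 4 is estimated at 6500 nM, in the range 2500 nM to 17000 nM.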

Compound 4, half-maximal inhibitory concentration: 3120 nM
Estimate against measurement, compound 4: 2.1-fold (0.32 log units) above; the range from low to high includes it.
By their numbers in this assay, from the lowest: compound 4; then compound 3; then compound 1. At a limit, above all of these: compound 2.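

In this assay, chloro on the aromatic carbon para to a hydroxy group gives a 2.7-fold lower number from compound 3 to compound 4 (0.43 log units; beyond the scatter), so a substituent within the 2-hydroxyphenyl arm moves the number beyond the scatter, which the exchanges of the whole group could not show. Against the 4-hydroxyphenyl arm, the 5-chloro-2-hydroxyphenyl arm gives a 7.0-fold lower number from compound 1 to compound 4 (0.84 log units; beyond the scatter). Against the pyridin-2-yl arm, the step is an at least 12-fold lower number from compound 2 to compound 4 (1.10 log units; beyond the scatter), and it is only a floor, as its starting value is a limit: the limit of >= 40000 nM in this assay, at which 1 of the 4 values shown sits.

Going by these compounds, it remains open whether fluoro, methoxy or an amine on this carbon would move the number as chloro does. On these data alone, it also remains open whether chloro on another carbon of this ring would do the same.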